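Ethyl on the aromatic hydroxy of compound 1

The source may hold more compounds than are shown below. What is called first, only, known or untested is meant among the compounds shown, and "the series" means these compounds.

For the measured compounds named here, compound 1 `Nc1nc(O)nc2c1nc(O)n2Cc1ccccc1` holds the only number in a functional assay (spleen, spleen) for activation, with Mus musculus as the target; a lower number here means that less compound is needed, a higher number that more compound is needed for the effect: compound 1 gives 0.1 uM. Compound 2 `Nc1ncnc2c1nc(Cl)n2Cc1ccccc1` reaches only the limit of this assay, where compound 2 gives > 10 uM; this is a limit, not a number (the limit of > 10 uM in this assay, at which 1 of the 2 values shown sits). Compound 3 `CCOc1nc(N)c2nc(O)n(Cc3ccccc3)c2n1` differs from compound 1 by ethyl in place of hydrogen on an oxygen on an aromatic ring. Going by the values given here, no measured step between two compounds is available, so the expected step rests on the change alone: a modest move toward less compound, beyond the scatter, is estimated for the step from compound 1 to compound 3 a 5.0-fold lower number from compound 1 to compound 3 (0.70 log units; beyond the scatter). Compound 3 is therefore expected at 0.02 uM, within a range from 0.003 uM to 0.1 uM.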

Compound 3, minimum effective concentration: 0.1 uM
Beside the measured number, compound 3's estimate is 5.0-fold (0.70 log units) below it; measured number inside the range.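

In this assay the step reads no change at the digits printed from compound 1 to compound 3 (within the scatter), the first step available at this position. The hydrogen on this oxygen can therefore give way to ethyl with no readable effect on the amount of compound needed, so a free hydroxy here is not required in this series. Nothing shown accounts for this flat step. On these data alone, whether a longer chain on the same oxygen, such as butyl, would also leave the value in place remains open. So does the effect of an amine in place of the hydroxy.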